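Solubility of two quaternary ammonium benzothiophene ketones and a third

The compounds below may be only part of what the source reports. "The series", "measured", "known", "first", "only" and "open" are said of these compounds alone.

Measured so far:
Compound 1, `COc1cc2cc(C(=O)CC3=CC[N+](C)(Cc4ccccc4)CC3)sc2cc1OC`: 20000 ug/mL
Compound 2, `COC(=O)C[N+]1(C)CCC(CCC(=O)c2cc3cc(OC)c(OC)cc3s2)CC1`: 60000 ug/mL

In a physicochemical assay for solubility (a higher number here means a more soluble compound, a lower number a less soluble compound), compound 2 gives 60000 ug/mL, the higher of the two numbers; its nearest neighbour, compound 1, gives 20000 ug/mL, and that gap lies beyond the scatter. The unmeasured compound 3, `COc1cc2cc(C(=O)CCC3CC[N+](C)(CC(=O)OC(C)(C)C)CC3)sc2cc1OC`, keeps the whole of compound 2 except at the ester, where it carries tert-butyl in place of methyl on an oxygen next to a carbonyl group. No step between two measured compounds isolates this kind of change, so nothing in the numbers shown says how large its effect will be. On the structural change alone, compound 3 is expected to sit somewhat below compound 2, with a step of a 2.0-fold lower number from compound 2 to compound 3 (0.30 log units; within the scatter) that may be no larger than the scatter. The expected value for compound 3 in this assay is therefore 30000 ug/mL, within a range from 10000 ug/mL to 80000 ug/mL.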

Compound 3, solubility: 1500 ug/mL
The estimate for compound 3 lay 20-fold (1.30 log units) above the measured number; the measured number lies below the stated range.
By their numbers in this assay, from the lowest: compound 3; then compound 1; then compound 2.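

In this assay, the group on this ester oxygen turns out to matter a great deal: tert-butyl in place of methyl gives a 40-fold lower number from compound 2 to compound 3 (1.60 log units; beyond the scatter) and nothing else in the structure changes. Among these compounds, this is the first step that isolates one change, so the earlier compounds could not show that this position alone can carry a large, clear drop in the read-out. No measurement shown accounts for the size of this drop.

The compounds shown leave open whether an ethyl or isopropyl ester would fall partway along this step or whether the drop appears only with tert-butyl. They also leave open how a carboxylic acid or a primary amide in place of the ester would read in this assay.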